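The compounds below may be only part of what the source reports. "The series", "measured", "known", "first", "only" and "open" are said of these compounds alone.

Working notes on the series. Compound 1 `COC(=O)N(C)CC#CCn1ccnc1` is the starting point; in a functional assay on the whole organism for antagonist activity, with Mus musculus as the target (on this read-out lower numbers stand for an effect already at smaller amounts and higher numbers for an effect only at larger amounts of compound), compound 1 gives > 100 mg/kg, which is a limit of the assay and not a number. Compound 2 `COC(=O)N(C)CC#CCN(C)C` carries the change (dimethylamino in place of 1H-imidazol-1-yl on a saturated chain carbon bound to a triple-bonded carbon). In this assay compound 2 gives > 30 mg/kg, again only a limit. The step that the two limits leave unreadable from compound 1 to compound 2 cannot be read, since both values sit at limits, namely the limit of > 100 mg/kg in this assay, at which 2 of the 3 values shown sit, and (the limit of > 30 mg/kg in this assay, at which 1 of the 3 values shown sits). Compound 3 `Cn1ccn(CC#CCn2ccnc2)c1=O` has a different core; the difference between the two cores is not broken down here. In this assay compound 3 gives > 100 mg/kg, a limit once more. Compound 4 `CN(C)CC#CCn1ccn(C)c1=O` is not yet measured and differs from compound 3 by the same change, (dimethylamino in place of 1H-imidazol-1-yl on a saturated chain carbon bound to a triple-bonded carbon), at the same place. The expected step is a number no higher from compound 3 to compound 4 (the limit leaves the size open), and this rests on the unreadable step that the two limits leave unreadable from compound 1 to compound 2 between two limits, so that no real shift is assumed. The expected value for compound 4 is estimated at 100 mg/kg, between 30 mg/kg and 300 mg/kg, most likely reported as a limit only.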

Compound 4, dose for half-maximal effect: > 100 mg/kg
Compound 4: no number, only a limit (the forecaster's own chance of this, stated with the estimate: 85%); the middle value lies on the limit itself.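

In this assay, within the data shown here, compound 3 and compound 4 each give only a limit of the assay and no number; no step between them can be read. The compounds shown leave open whether dimethylamino in place of 1H-imidazol-1-yl on a saturated chain carbon bound to a triple-bonded carbon shifts the dose for half-maximal effect at all, on either core.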